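The source may report more compounds than this note shows. Statements on the series, on what has been measured and on what is new or still open speak of the compounds shown alone.

Three compounds with a shared core were examined in a functional assay on the whole organism with Rattus norvegicus as the target; on this read-out lower numbers stand for an effect already at smaller amounts and higher numbers for an effect only at larger amounts of compound. Compound 1 `Nc1ccc2nc(N)sc2c1` returned only a limit, > 10 mg/kg, in this assay. Compound 2 `Nc1nc2ccc(OCC(F)(F)C(F)(F)F)cc2s1` gave 7.5 mg/kg in this assay. Compound 3 `COC(=O)Cn1c(=N)sc2cc(OC(F)(F)F)ccc21` also returned only a limit, > 10 mg/kg, in this assay. That leaves compound 3 standing at the limit of > 10 mg/kg in this assay, at which 2 of the 3 values shown sit, rather than at a number. Compound 4 `CSCCCn1c(=N)sc2cc(OC(F)(F)F)ccc21` has not yet been measured; it differs from compound 3 in one place: 2-(methylsulfanyl)ethyl in place of methoxycarbonyl on a saturated chain carbon bound to an aromatic nitrogen. No measured pair shows a comparable exchange, so the size of this step in this assay cannot be read from the numbers shown. The step that the limit leaves unreadable from compound 3 to compound 4 is expected to stay within the scatter. Compound 4 is therefore estimated at 12 mg/kg, between 5 mg/kg and 30 mg/kg, with a real chance that again only a limit is reported.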

Compound 4, dose for half-maximal effect: 4.2 mg/kg
The estimate for compound 4 lay 2.9-fold (0.46 log units) above the measured number; measured number below the stated range.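

In this assay, the saturated chain carbon bound to an aromatic nitrogen proves to be a place where one exchange moves the read-out: 2-(methylsulfanyl)ethyl in place of methoxycarbonyl gives an at least 2.3-fold lower number from compound 3 to compound 4 (0.37 log units; beyond the scatter). No earlier pair differing in one place had shown any step. The value for compound 3 is a limit, so this step has a floor but no exact size: the limit of > 10 mg/kg in this assay, at which 2 of the 4 values shown sit.

Going by these compounds, the exchange removes the carbonyl and brings in the sulfur together, and which of them carries the step stays open. On these data alone, how an amine, a carboxylic acid or a longer chain would read at this place also remains open.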